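The source may report more compounds than this note shows. Statements on the series, on what has been measured and on what is new or still open speak of the compounds shown alone.

Measured so far:
- compound 1, `N#C/C(=C\c1c(F)c(F)c(F)c(F)c1F)C(=O)c1c[nH]c2ccccc12`: 13000 nM
- compound 2, `COc1ccc(CNC(=O)/C(C#N)=C/c2ccc(Cl)o2)cc1`: 9000 nM

Both compounds were run in a functional assay on MCF7 cells (Homo sapiens) for inhibition, read by MTT assay, with a stated time of 72 h; a lower number here means a stronger inhibitor of growth, a higher number a weaker inhibitor of growth. Compound 1 gives 13000 nM, and compound 2 gives 9000 nM; these two numbers lie within the usual scatter of each other, so neither compound can be set apart from the other.

Compound 3, `COc1ccc(CNC(=O)/C(C#N)=C/c2ccc(C)cc2)cc1`, has not yet been measured. It differs from compound 2 in one place: 4-methylphenyl in place of 5-chlorofuran-2-yl on a double-bonded chain carbon bound to a double-bonded chain carbon. Within the data shown here, no measured pair shows this kind of exchange, so nothing in the data sets its size. Given the two similar values so far, only a modest shift is expected, if any beyond the scatter. The expected step is a 1.3-fold higher number from compound 2 to compound 3 (0.12 log units; within the scatter). Compound 3 is estimated at 12000 nM, with a likely range from 4000 nM to 40000 nM.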

Compound 3, concentration for 50% growth inhibition: 36000 nM
Estimate against measurement, compound 3: 3.0-fold (0.48 log units) below; measured number inside the range.
By their numbers in this assay, from the lowest: compounds 2 and 1 (each within the scatter of the next); then compound 3.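

Within this series, 4-methylphenyl in place of 5-chlorofuran-2-yl gives a 4.0-fold higher number from compound 2 to compound 3 (0.60 log units; beyond the scatter) in this assay and so weakens growth inhibition. Among these compounds, this is the first sign that the group on this double-bonded chain carbon can change the result, which compounds 1 and 2 could not show, as they differ in more than one place. Nothing available gives a reason for this step.

From the compounds shown here alone, the exchange changes the ring and its substituent together, so it remains open which of the two matters. A furan ring carrying methyl instead of chlorine, or a phenyl ring carrying chlorine instead of methyl, could separate them.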